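A few compounds are considered here, and "the series" means these few. Any claim that something is new, unique, unknown or untested is made for them only; others in the source may bear on it.

Compound 1 `CN1CCN(c2ccc(Nc3ncc4nc(Nc5ccccc5)n([C@@H]5CCNC5)c4n3)cc2)CC1` is the parent of this small set. In a functional assay on HCC827 cells (Homo sapiens) for antiproliferative activity, read by MTT assay, with a stated time of 72 h (a lower number here means a stronger inhibitor, a higher number a weaker inhibitor), compound 1 gives 65 nM, the lowest of the three numbers recorded. Compound 2 `CN1CCN(c2ccc(Nc3ncc4nc(Nc5ccc(F)cc5)n([C@@H]5CCNC5)c4n3)cc2)CC1` gives 300 nM, and the step of a 4.6-fold higher number from compound 1 to compound 2 (0.66 log units; beyond the scatter) comes from putting fluoro in place of hydrogen on an aromatic carbon. Compound 3 `CN1CCN(c2ccc(Nc3ncc4nc(Nc5ccc(F)cc5)n([C@H]5CCN(C(=O)CO)C5)c4n3)cc2)CC1` gives 380 nM; the step of a 1.3-fold higher number from compound 2 to compound 3 (0.10 log units; within the scatter) replaces pyrrolidin-3-yl with 1-((hydroxymethyl)carbonyl)pyrrolidin-3-yl on the aromatic nitrogen.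

Compound 4 `CN1CCN(c2ccc(Nc3ncc4nc(Nc5ccccc5)n([C@@H]5CCN(C(=O)OC(C)(C)C)C5)c4n3)cc2)CC1` is not yet measured. It differs from compound 1 by tert-butoxycarbonyl in place of hydrogen on an amine nitrogen in a ring. Going by the values given here, the only measured step that bears on this change is the one from compound 2 to compound 3, which also acylates the same ring nitrogen and stayed within the scatter, though with a smaller, hydroxyl-bearing group rather than tert-butoxycarbonyl. The fluoro step between compound 1 and compound 2 touches a different part of the molecule and does not speak to this change.

On that basis compound 4 is expected to sit close to compound 1, with at most a small shift toward a higher number, as a 1.5-fold higher number from compound 1 to compound 4 (0.19 log units; within the scatter) expresses. The estimate for compound 4 in this assay is therefore 100 nM, within a range of 40 nM to 300 nM.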

Compound 4, half-maximal inhibitory concentration: 12 nM
Estimate against measurement, compound 4: 8.3-fold (0.92 log units) above; measured number below the stated range.
By their numbers in this assay, from the lowest: compound 4; then compound 1; then compounds 2 and 3 (each within the scatter of the next).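

In this assay, the amine nitrogen of the pyrrolidin-3-yl group carries a large substituent not merely without loss but with a gain: replacing its hydrogen with tert-butoxycarbonyl gives a 5.4-fold lower number from compound 1 to compound 4 (0.73 log units; beyond the scatter) and makes compound 4 the lowest number of the set. The earlier change at this nitrogen, in the fluoro compounds, gave only a 1.3-fold higher number from compound 2 to compound 3 (0.10 log units; within the scatter) and so showed no gain, which means that the outcome of substitution here is not the same in every case, although those two steps differ in both the entering group and the fluoro background and cannot separate the two. Nothing in the information at hand gives a reason for the lower number of compound 4.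

As far as these compounds go, it remains open whether the gain is specific to tert-butoxycarbonyl or extends to other groups on this nitrogen, such as a simple acetyl, a methyl or a benzyloxycarbonyl. From the compounds shown here alone, it is also open whether tert-butoxycarbonyl would give a similar step in the fluoro series, starting from compound 2.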